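This account rests on a few compounds, and the source may have more. Where it says the series, first, only, none or still open, it means among the compounds named here.

Compound 3 `CC(Oc1ccc(Oc2ccc(F)cc2)cc1)C(=O)Cn1nnc(-c2ccc(C(=O)O)cc2)n1` is the analogue with a 4-fluorophenoxy group on the shared core carrying the aryl-tetrazole with its acid. In an ADME assay on S9 fraction from liver (Rattus norvegicus) for metabolic stability, read by LC-MS, using NADPH, with a stated time of 30 min (a lower number here means that less of the compound is left, a higher number that more of the compound is left), compound 3 gives 33%, the lowest of the two numbers shown in this series. Going by the values given here, the nearest comparison is compound 2 `CCCCCCCCc1ccc(OC(C)C(=O)Cn2nnc(-c3ccc(C(=O)O)cc3)n2)cc1`, which in this assay gives 55%; the step of a number 22 percentage points lower from compound 2 to compound 3 (beyond the scatter) is the only measured step in the set. Compound 1 `CC(Oc1ccc(Oc2ccc(Cl)cc2)cc1)C(=O)Cn1nnc(-c2ccccc2)n1`, which shares the 4-chlorophenoxy group with the unmeasured compound, returns in this assay only a limit, < 5%, not a number (the limit of < 5% in this assay, at which 1 of the 3 values shown sits).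

The unmeasured compound 4 `CC(Oc1ccc(Oc2ccc(Cl)cc2)cc1)C(=O)Cn1nnc(-c2ccc(C(=O)O)cc2)n1` differs from compound 3 by chloro in place of fluoro on an aromatic carbon. Among the compounds with values here, no measured step covers this exchange: the single measured step runs from octyl to 4-fluorophenoxy, a different kind of change at a different place, so it carries no direct weight for a halogen swap on the outer ring. With nothing in the data pointing one way, no step beyond the scatter is expected in this assay, so that compound 4 is estimated to sit near compound 3, an expected step of a number 3 percentage points lower from compound 3 to compound 4 (within the scatter).

The estimate for compound 4 in this assay is 30%, with a range from 15% to 48%.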

Compound 4, percent of the compound remaining: 32%
Estimate against measurement, compound 4: 2 percentage points below, within the range that was stated.
By their numbers in this assay, from the lowest: compounds 4 and 3 (each within the scatter of the next); then compound 2. At a limit, below all of these: compound 1.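

In this assay, the exchange on the outer ring, on an aromatic carbon para to a large group, does not separate the two halogens: a number 1 percentage points lower from compound 3 to compound 4 (within the scatter), so chloro and fluoro cannot be told apart at this place. The 4-chlorophenoxy group also stands apart from octyl on the same acid-bearing core, with a number 23 percentage points lower from compound 2 to compound 4 (beyond the scatter), so the step first seen with 4-fluorophenoxy now holds for a second phenoxy group, and compounds 3 and 4 both remain on the same side of compound 2. With the 4-chlorophenoxy group held, carboxy in place of hydrogen on an aromatic carbon gives a number at least 27 percentage points higher from compound 1 to compound 4 (beyond the scatter), the first reading of this change in the series, and that step starts from a limit for compound 1: the limit of < 5% in this assay, at which 1 of the 4 values shown sits.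

On these data alone, whether a methoxy or trifluoromethyl group at the same place would also stay within the scatter of chloro and fluoro remains open, since the series shows only these two atoms there. As far as these compounds go, it is equally open whether a primary amide in place of the carboxylic acid would keep the higher read-out that accompanies the carboxy group in compound 4.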